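This account rests on a few compounds, and the source may have more. Where it says the series, first, only, none or still open, it means among the compounds named here.

Measured compounds:
- Compound 1 `O=C(O)CCC(=O)N(C1CC1)[C@H]1c2ccccc2N(C(=O)c2ccc(OC(F)(F)F)cc2)[C@H]2CC[C@H]21`: 3.9 nM
- Compound 2 `O=C(O)COC(=O)N(C1CC1)[C@H]1c2ccccc2N(C(=O)c2cccc(F)c2)[C@H]2CC[C@H]21`: 13 nM
- Compound 3 `O=C(O)COC(=O)N(C1CC1)[C@H]1c2ccccc2N(C(=O)c2ccc(F)cc2)[C@H]2CC[C@H]21`: 3.6 nM

In a functional assay for antagonist activity at prostaglandin D2 receptor 2 (Homo sapiens), read by flow cytometry, with stated times of 10 min and 4 min (a lower number here means a stronger inhibitor, a higher number a weaker inhibitor), compound 3 gives 3.6 nM, the lowest of the three numbers, but compound 1 at 3.9 nM lies within the scatter of it, so the two cannot be ranked; only compound 2 at 13 nM stands clearly apart, as the step of a 3.6-fold lower number from compound 2 to compound 3 (0.56 log units; beyond the scatter) shows.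

Compound 4 `O=C(O)COC(=O)N(C1CC1)[C@H]1c2ccccc2N(C(=O)c2ccc(OC(F)(F)F)cc2)[C@H]2CC[C@H]21` is compound 3 with one change: trifluoromethoxy in place of fluoro on an aromatic carbon. Among the compounds with values here, no measured step shows this exact exchange. Compound 1 carries the same trifluoromethoxy group on the same ring, yet it also differs from compound 3 in the acid-bearing chain, so only its value is informative: compound 1 and compound 3 sit within the scatter of each other. On that basis the exchange is expected to leave this assay essentially unchanged, and the step of a 1.1-fold higher number from compound 3 to compound 4 (0.05 log units; within the scatter) is estimated to fall within the scatter. Compound 4 is therefore expected to give about 4 nM, with a likely range from 1.5 nM to 11 nM.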

Compound 4, half-maximal inhibitory concentration: 8.2 nM
Compound 4: middle estimate off by 2.1-fold (0.31 log units), on the low side; low and high end bracket the measured number.
By their numbers in this assay, from the lowest: compounds 3 and 1 (each within the scatter of the next); then compounds 4 and 2 (each within the scatter of the next).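

In this assay, within the data shown here, trifluoromethoxy on this aromatic carbon does not match fluoro: the exchange gives a 2.3-fold higher number from compound 3 to compound 4 (0.36 log units; beyond the scatter), a modest loss that the earlier compounds could not reveal. The acid-bearing chain also counts with trifluoromethoxy in place, since carboxymethoxy instead of 2-carboxyethyl gives a 2.1-fold higher number from compound 1 to compound 4 (0.32 log units; beyond the scatter), again a modest loss. Replacing the 3-fluorophenyl group with 4-(trifluoromethoxy)phenyl gives a 1.6-fold lower number from compound 2 to compound 4 (0.20 log units; within the scatter), which lies within the scatter, so these two compounds cannot be ranked.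

Nothing available explains why either change shifts the number. Still open, from the compounds shown here alone, is whether chloro or trifluoromethyl on the same aromatic carbon would track fluoro or trifluoromethoxy, and how the 2-carboxyethyl chain behaves alongside the 4-fluorophenyl group.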